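The source may report more compounds than this note shows. Statements on the series, on what has been measured and on what is new or still open speak of the compounds shown alone.

Measured in a functional assay on MDA-MB-231 cells (Homo sapiens) for cytotoxicity, read by MTT assay, with a stated time of 72 h; on this read-out lower numbers stand for stronger inhibition and higher numbers for weaker inhibition:
- compound 1 `Nc1ccccc1NC(=O)c1ccc(NC(=S)NCc2ccc(Cl)nc2)cc1`: 42000 nM
- compound 2 `Nc1ccccc1NC(=O)c1ccc(NC(=O)/C(Cl)=C(\Cl)c2cccnc2)cc1`: 13000 nM
- compound 3 `Nc1ccccc1NC(=O)c1ccc(NC(=O)NCc2ccc(Cl)nc2)cc1`: 34000 nM

Compound 1, at 42000 nM, cannot be told apart from compound 3, at 34000 nM. The two lie within the usual scatter of repeated measurements. Compound 2, at 13000 nM, gives a lower number than compound 1, and that gap lies beyond the scatter. Compound 1 therefore sits at the weak end of this small set, level with compound 3.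

The next compound is compound 4 `Nc1ccccc1NC(=O)c1ccc(NC(=S)NCc2cncc(Br)c2)cc1`, which keeps the core of compound 1 and changes one group: 5-bromopyridin-3-yl in place of 6-chloropyridin-3-yl on a saturated chain carbon bound to an amide-type nitrogen. In words, 5-bromopyridin-3-yl stands in place of 6-chloropyridin-3-yl on a saturated chain carbon bound to an amide-type nitrogen.

Going by the values given here, no pair of measured compounds shows this exchange or any other single change, so the only anchor is compound 1 at 42000 nM. The exchange swaps one halogen-bearing pyridine group for another of the same size, so no large shift is expected. The expected move is a 1.3-fold lower number from compound 1 to compound 4 (0.12 log units; within the scatter), a small drop toward lower numbers that stays within the scatter. For compound 4 the estimated value in this assay is 32000 nM, with an expected range from 13000 nM to 75000 nM.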

Compound 4, half-maximal inhibitory concentration: 39000 nM
Compound 4: middle estimate off by 1.2-fold (0.09 log units), on the low side, and the stated range covers the measured number.
By their numbers in this assay, from the lowest: compound 2; then compounds 3, 4 and 1 (each within the scatter of the next).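

In this assay, going by these compounds alone, putting 5-bromopyridin-3-yl in place of 6-chloropyridin-3-yl on a saturated chain carbon bound to an amide-type nitrogen gives a 1.1-fold lower number from compound 1 to compound 4 (0.03 log units; within the scatter) and is the first comparison in this set in which only one place differs. The earlier compounds shown here differ from one another in more than one place, so they could not isolate this group; this pair shows that one halogen-bearing pyridine group can stand in for the other, with the same count of heavy atoms, without a change that can be told from the scatter. Nothing measured here offers a reason for this outcome.

The exchange alters both the halogen and its place on the pyridine ring, so this single pair cannot separate those two changes, and they could have effects that cancel. Also open, from the compounds shown here alone, is whether a carboxylic acid or an amine in place of the halogen, or a longer chain in place of the methyl link, would move the number in this assay beyond the scatter.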